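This account rests on a few compounds, and the source may have more. Where it says the series, first, only, none or still open, it means among the compounds named here.

Of the compounds shown here, three built on the same core have been measured in a functional assay on HEK293 cells for agonist activity at D(4) dopamine receptor (Homo sapiens), read by FLIPR; on this read-out higher numbers stand for an effect only at larger amounts of compound and lower numbers for an effect already at smaller amounts. Compound 1 `CCc1cccc(NC(=O)CN2CCC(c3cccc[n+]3[O-])CC2)c1` gives 95 nM. Compound 2 `Cc1cc(F)ccc1NC(=O)CN1CCC(c2cccc[n+]2[O-])CC1` gives 60 nM, and compound 3 `Cc1cccc(C)c1NC(=O)CN1CCC(c2cccc[n+]2[O-])CC1` gives 346 nM. Among these three numbers compound 1 stands second highest; its nearest neighbour is compound 2, where the step is a 1.6-fold lower number from compound 1 to compound 2 (0.20 log units; within the scatter), and its furthest is compound 3, where the step is a 3.6-fold higher number from compound 1 to compound 3 (0.56 log units; beyond the scatter). Between the other two the step is a 5.8-fold higher number from compound 2 to compound 3 (0.76 log units; beyond the scatter).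

Compound 4 `O=C(CN1CCC(c2cccc[n+]2[O-])CC1)Nc1cccc(C(F)(F)F)c1` has not yet been measured. It differs from compound 1 by trifluoromethyl in place of ethyl on an aromatic carbon. For the measured compounds named here, none of the measured steps swaps one group for another at this same place; all of them rearrange the pattern of groups around the ring, and even the largest of them stayed modest. The step from compound 1 to compound 4 is therefore expected to be small, most likely within the scatter, with no clear direction: a 1.2-fold higher number from compound 1 to compound 4 (0.06 log units; within the scatter). For compound 4 the estimate in this assay is 110 nM, ranging from 40 nM to 300 nM.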

Compound 4, half-maximal effective concentration: 76 nM
The estimate for compound 4 lay 1.4-fold (0.16 log units) above the measured number, and the stated range covers the measured number.
By their numbers in this assay, from the lowest: compounds 2, 4 and 1 (each within the scatter of the next); then compound 3.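

Trifluoromethyl in place of ethyl, on an aromatic carbon meta to a large group, is the first swap of one group for another at this place, and in this assay it gives a 1.3-fold lower number from compound 1 to compound 4 (0.10 log units; within the scatter). The earlier steps shown here changed the pattern of groups around the ring, whereas this one shows that a group of three fluorines on one carbon can replace a two-carbon group here with no difference that this read-out can separate from scatter. No measurement at hand explains why these two groups read alike.

Both groups shown at this carbon have no hydrogen-bond donors or acceptors and no net charge, so the outcome with an amine, a carboxylic acid or a longer chain stays open. From the compounds shown here alone, it is also open whether trifluoromethyl would read the same on another aromatic carbon.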